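The compounds below may be only part of what the source reports. "The series", "measured", "known", "first", "only" and "open" are said of these compounds alone.

Measured compounds:
- compound 1 `COC1=C(C)C(=O)/C(=C(O)/C=C/c2cccc(OC)c2)C(=O)C1(C)C` — 2.9 ug/mL
- compound 2 `COC1=C(C)C(=O)/C(=C(O)/C=C/c2ccccc2C)C(=O)C1(C)C` — "not determined" (no result reported)

Compound 2 stands nowhere on the numbers shown: in a functional assay on 1A9 cells (Homo sapiens) for cytotoxicity (on this read-out lower numbers stand for an effect already at smaller amounts and higher numbers for an effect only at larger amounts of compound), compound 2 gave "not determined" (no result reported), so no value anchors it. For the measured compounds named here, the only number is that of compound 1, which in this assay gives 2.9 ug/mL. Compound 3 `COC1=C(C)C(=O)/C(=C(O)/C=C/c2cccs2)C(=O)C1(C)C` differs from compound 2 by thiophen-2-yl in place of 2-methylphenyl on a double-bonded chain carbon bound to a double-bonded chain carbon. Going by the values given here, no measured pair shows what this change does, and no step can be drawn from compound 2, which carries no number. With compound 1 as the only reference, the expectation for compound 3 in this assay is a result in the same region as compound 1, with no direction claimed beyond the scatter of the read-out. For compound 3 the estimated value in this assay is 3 ug/mL, expected to lie between 0.8 ug/mL and 12 ug/mL.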

Compound 3, concentration for half-maximal effect: 4 ug/mL
Estimate against measurement, compound 3: 1.3-fold (0.12 log units) below; measured number inside the range.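

In this assay, this position now has its first readable step: thiophen-2-yl in place of 3-methoxyphenyl on a double-bonded chain carbon bound to a double-bonded chain carbon gives a 1.4-fold higher number from compound 1 to compound 3 (0.14 log units; within the scatter). On the shared core, the 3-methoxyphenyl group of compound 1 can therefore be exchanged for the thiophen-2-yl group of compound 3 with no difference beyond the scatter of the read-out. No measurement of any property of these groups bears on this result.

Compound 2 has no number, so steps to or from it cannot be read, and the 2-methylphenyl group stays unplaced. Also open, on these data alone, is whether a group other than these aromatic rings, such as an amine, a carboxylic acid or a longer alkyl chain, at this place keeps the result in the same region.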